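Ethylcarbamoyl in place of methylcarbamoyl: notes on compound 4

The source may hold more compounds than are shown below. What is called first, only, known or untested is meant among the compounds shown, and "the series" means these compounds.

Values in an ADME assay on HeLa cells (Homo sapiens) for cytotoxicity, read by crystal violet staining, with a stated time of 72 h (a lower number here means that less compound is tolerated, a higher number that more compound is tolerated), are as follows.
- compound 1 `COC(=O)c1cc(CCCOc2c(C)cc(-c3noc(C(F)(F)F)n3)cc2C)on1` gives 35400 nM
- compound 2 `COc1ccc(-c2cc(CCCOc3c(C)cc(-c4noc(C(F)(F)F)n4)cc3C)on2)cc1OC` gives 41900 nM
- compound 3 `CNC(=O)c1cc(CCCOc2c(C)cc(-c3noc(C(F)(F)F)n3)cc2C)on1` gives > 100000 nM (a limit, not a number)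

Compound 3 sits at the limit of > 100000 nM in this assay, at which 1 of the 3 values shown sits, and has no number of its own. Compound 4 `CCNC(=O)c1cc(CCCOc2c(C)cc(-c3noc(C(F)(F)F)n3)cc2C)on1` differs from compound 3 by methyl in place of hydrogen on a saturated chain carbon bound to an amide-type nitrogen in the change of methylcarbamoyl to ethylcarbamoyl. Within the data shown here, no measured step alters this chain. The closest are an at least 2.8-fold higher number from compound 1 to compound 3 (0.45 log units; beyond the scatter) and an at least 2.3-fold higher number from compound 2 to compound 3 (0.37 log units; beyond the scatter) while a 1.2-fold higher number from compound 1 to compound 2 (0.07 log units; within the scatter) adds little. Compound 4 keeps the amide, and no step beyond the scatter is expected in this assay here. The expected change is an at least 1.1-fold lower number from compound 3 to compound 4 (0.04 log units; that floor lies within the scatter) and another report at the limit is possible. For compound 4 the estimated value is 90000 nM with a range from 40000 nM to 150000 nM as the expected span.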

Compound 4, half-maximal cytotoxic concentration: > 100000 nM
Compound 4 was reported as a limit; the forecaster's own chance of this, stated with the estimate: 50%; middle value at least 1.1-fold (0.04 log units) from the limit.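

In this assay compound 4 also gives a limit, > 100000 nM, and not a number. Ethylcarbamoyl keeps the separation seen with methylcarbamoyl, with an at least 2.8-fold higher number from compound 1 to compound 4 (0.45 log units; beyond the scatter) and an at least 2.3-fold higher number from compound 2 to compound 4 (0.37 log units; beyond the scatter). The step from compound 3 to compound 4 cannot be read, as both values are limits: the limit of > 100000 nM in this assay, at which 2 of the 4 values shown sit.

Going by these compounds, how far either amide lies beyond this limit remains open. Also open, on these data alone, is whether a propyl amide, a dimethylamide or a carboxylic acid on this carbonyl carbon would stay at the limit.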